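Sulfonyl substituent swap in a pyridinylethynyl tetrahydropyridine series

The source may report more compounds than this note shows. Statements on the series, on what has been measured and on what is new or still open speak of the compounds shown alone.

Measured so far:
compound 1, `O=C1c2ccccc2C(=O)N1C1C=C(C#Cc2ccccn2)CCC1`: 27 nM
compound 2, `O=S(=O)(Cc1ccccc1)N1CC=C(C#Cc2ccccn2)CC1`: 58 nM

In an in vitro functional assay on Ltk cells for inhibition of metabotropic glutamate receptor 5 (Homo sapiens), read by calcium flux (a higher number here means a weaker inhibitor, a lower number a stronger inhibitor), compound 1 gives 27 nM and compound 2 gives 58 nM. Compound 2 thus stands with the higher of the two numbers, and its gap to compound 1 lies beyond the usual scatter, so compound 1 is the stronger inhibitor of the pair. Among the measured compounds shown here, the two differ in more than one place, so no single step is counted between them.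

Compound 3, `Cc1ccc(S(=O)(=O)N2CC=C(C#Cc3ccccn3)CC2)cc1`, differs from compound 2 by 4-methylphenyl in place of benzyl on a sulfonyl sulfur. For the measured compounds named here, no measured pair in the set isolates a change on the sulfonyl sulfur, so the expectation rests on compound 2 alone. The step of a 1.3-fold lower number from compound 2 to compound 3 (0.11 log units; within the scatter) is expected to be small, of uncertain direction, and not beyond the scatter. Compound 3 is estimated at 45 nM, with a range from 12 nM to 170 nM.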

Compound 3, half-maximal inhibitory concentration: 7.9 nM
Estimate against measurement, compound 3: 5.7-fold (0.76 log units) above, and the stated range ends above it.
By their numbers in this assay, from the lowest: compound 3; then compound 1; then compound 2.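

The sulfonyl sulfur is a position where the substituent matters: in this assay, replacing benzyl with 4-methylphenyl gives a 7.3-fold lower number from compound 2 to compound 3 (0.87 log units; beyond the scatter) even though both groups have the same heavy-atom count and one six-membered aromatic ring of carbon only. The counts under comparison therefore do not predict the result at this position; the two groups differ only in how the same atoms are joined. No measurement bearing on the origin of this step is available.

The compounds shown do not separate the effect of attaching the aromatic ring directly to the sulfonyl sulfur from that of its methyl group, a question that plain phenyl at this position could address. From the compounds shown here alone, how an amine or a carboxylic acid on that ring would fare also remains open.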